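This account rests on a few compounds, and the source may have more. Where it says the series, first, only, none or still open, it means among the compounds named here.

Working notes on the series. In an assay (Equus caballus) for inhibition of Thromboxane-A synthase (Homo sapiens), using microsomes (a higher number here means a weaker inhibitor, a lower number a stronger inhibitor), compound 1, `CSC(CCC/C=C(\c1ccccc1)c1cccnc1)C(=O)O`, gives 30 nM. Compound 2, `O=C(O)CCCC/C=C(\c1cccnc1)c1cccc(Br)c1`, gives 180 nM in this assay, and compound 3, `C/C(=C\CCCCC(=O)O)c1cccnc1`, gives 210 nM. Among the three measured compounds, compound 1 stands at the lowest number; both compound 2 and compound 3 lie above it by more than the usual scatter, so on these numbers compound 1 is the strongest inhibitor of the set. Compound 2 and compound 3 lie within the scatter of each other, so nothing is read into their order.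

Compound 4, `COC(=O)CCCC/C=C(\c1ccccc1)c1cccnc1`, has not been measured in this assay. It differs from compound 1 in one place: (methoxycarbonyl)methyl in place of carboxy(methylsulfanyl)methyl on a saturated chain carbon, three bonds along the chain from a double-bonded chain carbon. The acid of compound 1 is thereby replaced by a methyl ester and the methylsulfanyl group is lost; compound 4 keeps the double bond, the phenyl and the pyridyl ring of compound 1 unchanged. Going by the values given here, no measured pair in the set isolates either part of this change, so there is no direct precedent to lean on. The expectation is a weaker inhibitor, with the step from compound 1 to compound 4 estimated as a 10-fold higher number from compound 1 to compound 4 (1.00 log units; beyond the scatter), beyond the scatter. Compound 4 is estimated at 300 nM in this assay, with a range from 80 nM to 1500 nM.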

Compound 4, half-maximal inhibitory concentration: 100 nM
The estimate for compound 4 lay 3.0-fold (0.48 log units) above the measured number; measured number inside the range.
By their numbers in this assay, from the lowest: compound 1; then compounds 4, 2 and 3 (each within the scatter of the next, the first and the last beyond it).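

Going by these compounds alone, the step at this position can now be read for the first time: in this assay, a 3.3-fold higher number from compound 1 to compound 4 (0.52 log units; beyond the scatter) is modest, though beyond the scatter. Putting (methoxycarbonyl)methyl in place of carboxy(methylsulfanyl)methyl removes the sulfur and the one hydrogen-bond donor of the group, yet compound 4 still gives 100 nM, so neither the free carboxy group nor the methylsulfanyl group is needed for inhibition at this level, although compound 1 with both remains the lower number. No data bearing on the reason for this step are available.

The two parts of the change remain joined in this one step: a 2-carboxyethyl group, which keeps the free acid without the methylsulfanyl group, and a methyl ester that keeps the methylsulfanyl group would show how the step divides between them. It also stays open how this place responds to a primary amide, an ethyl ester or a longer chain ending in a carboxylic acid, since the compounds shown give only one replacement on the shared core.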